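The source may hold more compounds than are shown below. What is called first, only, known or untested is meant among the compounds shown, and "the series" means these compounds.

Compound 3, `O=C(C1=C(Nc2ccc(F)cc2)C(=O)N(CCCn2ccnc2)C1c1ccc(Br)cc1)c1ccccc1`, sits among three measured analogues sharing one core: compound 1, `CCCCOC1=C(C(=O)c2ccccc2)C(c2ccc(Br)cc2)N(CCCn2ccnc2)C1=O`, and compound 2, `O=C(C1=C(OC2CCCCC2)C(=O)N(CCCn2ccnc2)C1c1ccc(Br)cc1)c1ccccc1`. In a functional assay on U2OS cells (Homo sapiens) for antiproliferative activity, read by MTT assay, with a stated time of 72 h (on this read-out lower numbers stand for stronger inhibition and higher numbers for weaker inhibition), compound 1 gives 32400 nM, compound 2 gives 22400 nM, and compound 3 gives 30000 nM. Compound 3 therefore stands second highest of the three, closest to compound 1 and furthest from compound 2, though every gap lies within the scatter: a 1.4-fold lower number from compound 1 to compound 2 (0.16 log units; within the scatter), a 1.1-fold lower number from compound 1 to compound 3 (0.03 log units; within the scatter) and a 1.3-fold higher number from compound 2 to compound 3 (0.13 log units; within the scatter).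

Compound 4, `O=C(C1=C(Nc2ccc(Br)cc2)C(=O)N(CCCn2ccnc2)C1c1ccc(Br)cc1)c1ccccc1`, differs from compound 3 in one place: bromo in place of fluoro on an aromatic carbon. For the measured compounds named here, no measured step swaps one halogen for another; the steps that touch the same ring carbon, from compound 1 to compound 3 and from compound 2 to compound 3, exchange the whole group at that position and still stay within the scatter. Given how flat this series is, no step beyond the scatter is expected in this assay from compound 3 to compound 4, the expected step being a 1.1-fold lower number from compound 3 to compound 4 (0.05 log units; within the scatter). Compound 4 is therefore estimated at 27000 nM, with a range from 12000 nM to 60000 nM.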

Compound 4, half-maximal inhibitory concentration: 13000 nM
Beside the measured number, compound 4's estimate is 2.1-fold (0.32 log units) above it; the measured number falls inside the stated range.
By their numbers in this assay, from the lowest: compounds 4, 2, 3 and 1 (each within the scatter of the next, the first and the last beyond it).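

Swapping a single halogen on the aromatic ring moves the number beyond the scatter (a 2.3-fold lower number from compound 3 to compound 4 (0.36 log units; beyond the scatter)), which no step among the earlier compounds did, so this ring carbon responds to a change that whole-group exchanges at the double-bonded ring carbon had not produced. With bromo in place, the exchange at the double-bonded ring carbon gives a modest step beyond the scatter from the butoxy compound (a 2.5-fold lower number from compound 1 to compound 4 (0.40 log units; beyond the scatter)), while the step from the cyclohexyloxy compound stays within it (a 1.7-fold lower number from compound 2 to compound 4 (0.24 log units; within the scatter)). Nothing given here accounts for the halogen step in terms of any measured property.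

The compounds shown leave open whether chloro, iodo or methyl on that aromatic carbon would track with bromo or with fluoro. They also leave open whether the bromo step persists when the 4-bromophenyl group on the shared core is replaced by another group, such as a pyridine ring.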